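Nitro to amino on the hydroxy compound

The source may report more compounds than this note shows. Statements on the series, on what has been measured and on what is new or still open speak of the compounds shown alone.

- compound 1 (`O=[N+]([O-])c1ccc(S(=O)(=O)Nc2cccc3cc[nH]c23)cc1`) in a functional assay on MC-38 cells (Mus musculus) for antiproliferative activity, read by colorimetric assay and MTT assay (on this read-out lower numbers stand for stronger inhibition and higher numbers for weaker inhibition), gives 7.2 ug/mL as its value
- compound 2 (`O=[N+]([O-])c1ccc(S(=O)(=O)Nc2cccc3cc(O)[nH]c23)cc1`) in this assay gives 62 ug/mL as its value

Compound 2 holds the higher of the two numbers in this assay and is the weaker of the pair. Within the data shown here, the only measured step is an 8.6-fold higher number from compound 1 to compound 2 (0.94 log units; beyond the scatter) and it lies beyond the scatter.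

The next structure, compound 3 (`Nc1ccc(S(=O)(=O)Nc2cccc3cc(O)[nH]c23)cc1`), keeps the hydroxy group of compound 2 and carries amino in place of nitro on an aromatic carbon, para to a large group (amino in place of nitro on an aromatic carbon). Among the measured compounds shown here, no measured step covers this exchange. The step of an 8.6-fold higher number from compound 1 to compound 2 (0.94 log units; beyond the scatter) concerns the hydroxy group on the shared core and not the nitro group, so it serves only as a gauge of how far a single change has moved the numbers in this series.

A step of similar size or smaller is therefore expected in this assay for the exchange. The data fix no direction, and a modest move toward a lower number is only a working expectation. The estimated change is a 2.1-fold lower number from compound 2 to compound 3 (0.32 log units; beyond the scatter) and carries little certainty. For compound 3 the estimated value is 30 ug/mL with an expected range from 7 ug/mL to 110 ug/mL in this read-out.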

Compound 3, half-maximal inhibitory concentration: 1.8 ug/mL
For compound 3 the middle estimate is 17-fold (1.22 log units) above the measured one; measured number below the stated range.
By their numbers in this assay, from the lowest: compound 3; then compound 1; then compound 2.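

In this assay, the ring position para to a large group proves highly responsive: with the hydroxy group held in place, amino in place of nitro gives a 34-fold lower number from compound 2 to compound 3 (1.54 log units; beyond the scatter). This step runs opposite in direction to an 8.6-fold higher number from compound 1 to compound 2 (0.94 log units; beyond the scatter) and is the larger of the two, so the higher number seen with the hydroxy group on the shared core is not fixed, and compound 3 reaches 1.8 ug/mL with that group still present. The exchange replaces three heavy atoms with one and adds a hydrogen-bond donor, but nothing available here links either difference to the size of the step.

Still open, on these data alone, is whether amino at this position would produce a step of similar size and direction on the core of compound 1, without the hydroxy group, since the two changes are seen here only in sequence. Also open, as far as these compounds go, is how much depends on amino itself; a dimethylamino group, an acetamido group or plain hydrogen at the same place would help separate the effect of adding amino from that of removing nitro.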